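From 4-methylphenyl to cyclohexyl on a shared core

A few compounds are considered here, and "the series" means these few. Any claim that something is new, unique, unknown or untested is made for them only; others in the source may bear on it.

In a functional assay on A549 cells (Homo sapiens) for cytotoxicity, read by MTT assay, with a stated time of 72 h (on this read-out lower numbers stand for stronger inhibition and higher numbers for weaker inhibition), compound 1 (`O=C(Nc1nnc(-c2cccc(O)c2O)s1)c1ccc(Cl)cc1`) gives 9500 nM and compound 2 (`Cc1ccc(C(=O)Nc2nnc(-c3cccc(O)c3O)s2)cc1`) gives 11300 nM. Within the data shown here, the only measured step is a 1.2-fold higher number from compound 1 to compound 2 (0.08 log units; within the scatter), so compound 2 stands level with the one other measured compound. Compound 3 (`O=C(Nc1nnc(-c2cccc(O)c2O)s1)C1CCCCC1`) has cyclohexyl in place of 4-methylphenyl on a carbonyl carbon. The measured step, methyl in place of chloro on an aromatic carbon, bears on this change only loosely, since it keeps the aromatic ring. Among the measured compounds shown here, no measured step replaces that ring, so the data give no direct size for such a swap. Starting from compound 2 at 11300 nM, no shift beyond the scatter is expected in this assay, and no direction can be favoured. The estimate amounts to an expected 1.1-fold higher number from compound 2 to compound 3 (0.03 log units; within the scatter). Compound 3 is expected at 12000 nM, within an estimated range of 5000 nM to 30000 nM.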

Compound 3, half-maximal inhibitory concentration: 11000 nM
Estimate against measurement, compound 3: 1.1-fold (0.04 log units) above; the range from low to high includes it.
By their numbers in this assay, from the lowest: compounds 1, 3 and 2 (each within the scatter of the next).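

In this assay the exchange of an aromatic ring for cyclohexyl on the carbonyl carbon gives a 1.0-fold lower number from compound 2 to compound 3 (0.01 log units; within the scatter) and a 1.2-fold higher number from compound 1 to compound 3 (0.06 log units; within the scatter) and so stays within the scatter from both aromatic compounds. The earlier pair varied only a group on the aromatic ring, whereas compound 3 shows that, on this shared core, a non-aromatic ring of carbon only gives a value level with those of compound 1 and compound 2. Nothing at hand accounts for this level result.

On these data alone, whether other groups on this carbonyl carbon, such as an amine, a carboxylic acid or a longer alkyl chain, would also stay level remains open. The hydroxyl groups on the shared core are the same in all three compounds, so what they contribute is also unresolved.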